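Furan to Phenyl on the Arm Beside the Amide Nitrogen

The source may hold more compounds than are shown below. What is called first, only, known or untested is meant among the compounds shown, and "the series" means these compounds.

Within the data shown here, compound 2 `CCN(Cc1ccco1)C(=O)COc1ccc(C)cc1` gives 489 nM in an assay on HEK293 cells for agonist activity at transient receptor potential cation channel subfamily M member 8 (Homo sapiens), read by fluorescence and calcium flux, with a stated time of 15 min (a lower number here means that less compound is needed, a higher number that more compound is needed for the effect), the higher of the two measured numbers; compound 1 `CCN(Cc1ccc(C)s1)C(=O)COc1ccc(C)cc1` gives 178 nM, and the single measured step, a 2.7-fold higher number from compound 1 to compound 2 (0.44 log units; beyond the scatter), shifted the number upward. Compound 3 `CCN(Cc1ccccc1)C(=O)COc1ccc(C)cc1` differs from compound 2 by phenyl in place of furan-2-yl on a saturated chain carbon bound to an amide-type nitrogen. Among the measured compounds shown here, no measured step compares phenyl with either five-membered ring, so that one step bears on the question only loosely. Compound 3 is expected to fall between the two measured values, with an estimated 2.0-fold lower number from compound 2 to compound 3 (0.29 log units; within the scatter). The estimate for compound 3 is 250 nM, within 100 nM to 650 nM.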

Compound 3, half-maximal effective concentration: 1880 nM
Compound 3: the middle estimate sits 7.5-fold (0.88 log units) below what was measured, and the stated range ends below it.
By their numbers in this assay, from the lowest: compound 1; then compound 2; then compound 3.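

At this place, on a saturated chain carbon bound to an amide-type nitrogen, this assay shows phenyl costing more than either five-membered ring: a 3.8-fold higher number from compound 2 to compound 3 (0.58 log units; beyond the scatter) and an 11-fold higher number from compound 1 to compound 3 (1.02 log units; beyond the scatter) place it highest of the three. The earlier pair compared only furan-2-yl with 5-methylthiophen-2-yl, so this ring-size contrast is new. Nothing available explains the order.

As far as these compounds go, it remains open how thiophen-2-yl without its methyl would read, which would separate the ring from the methyl in compound 1. Also open, from the compounds shown here alone, is whether a 4-methylphenyl or a pyridin-2-yl would stand nearer phenyl or the five-membered rings.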